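This account rests on a few compounds, and the source may have more. Where it says the series, first, only, none or still open, it means among the compounds named here.

Compound 1 `CCC(=O)NCc1ccc(C(=O)Nc2ccc(C)c(Nc3nccc(-c4cccnc4)n3)c2)cc1`: in an ADME assay on BaF3 cells (Mus musculus) for cytotoxicity, read by CellTiter-Glo and CCK-8 assay, with a stated time of 72 h (on this read-out lower numbers stand for stronger inhibition of growth and higher numbers for weaker inhibition of growth), compound 1 gives > 10000 nM, which is a limit of the assay rather than a number.
Compound 2 `Cc1ccc(NC(=O)c2ccc(CN(CCN(C)C)C(=O)C(C)(C)C)cc2)cc1Nc1nccc(-c2cccnc2)n1`: in this assay compound 2 gives > 10000 nM, likewise only a limit.

Compound 2 thus stands at the limit, where both measured values sit. Among the measured compounds shown here, the single measured step, a step that the two limits leave unreadable from compound 1 to compound 2, cannot be sized because of the limit of > 10000 nM in this assay, at which 2 of the 2 values shown sit. Compound 3 `C=CC(=O)N(CCC(C)C)Cc1ccc(C(=O)Nc2ccc(C)c(Nc3nccc(-c4cccnc4)n3)c2)cc1` differs from compound 2 by isopentyl(vinylcarbonyl)amino in place of (2-(dimethylamino)ethyl)((tert-butyl)carbonyl)amino on a saturated chain carbon bound to an aromatic carbon. For the measured compounds named here, no measured step carries a readable size for this change, so no direction beyond the scatter can be expected. Compound 3 is therefore expected to give 12000 nM, from 3000 nM to 40000 nM, an expected step that the limit leaves unreadable from compound 2 to compound 3, most likely again reported only as a limit.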

Compound 3, concentration for 50% growth inhibition: 5620 nM
Compound 3: middle estimate off by 2.1-fold (0.33 log units), on the high side; measured number inside the range.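

Among the compounds shown here, compound 3 is the first compound here to give a number rather than a limit in this assay, with isopentyl(vinylcarbonyl)amino on a saturated chain carbon bound to an aromatic carbon. The steps read as an at least 1.7-fold lower number from compound 2 to compound 3 (0.25 log units; that floor lies within the scatter) and as an at least 1.7-fold lower number from compound 1 to compound 3 (0.25 log units; that floor lies within the scatter), and the step between the two earlier compounds cannot be read. Both readable steps are only floors, because their starting values are limits: the limit of > 10000 nM in this assay, at which 2 of the 3 values shown sit.

Isopentyl and vinylcarbonyl enter together, so the compounds shown leave open which of them matters. A longer chain such as hexyl in place of isopentyl, or a morpholine, would test the chain alone.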